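Swapping a fused bicyclic amide group for a methoxyphenyl

The compounds below may be only part of what the source reports. "The series", "measured", "known", "first", "only" and "open" are said of these compounds alone.

Of the compounds shown here, three sharing one core have been measured in an assay on isolated protein for inhibition of histone acetyltransferase p300 (Homo sapiens), with a stated time of 60 min; a lower number here means a stronger inhibitor, a higher number a weaker inhibitor. Compound 1 `COc1ccc(NC(=O)[C@H]2CCCN2C(=O)C2(c3cccc(Cl)c3)CCCC2)nc1` gives 2 nM. Compound 2 `O=C(Nc1ccc2[nH]ccc2n1)[C@H]1CCCN1C(=O)C1(c2cccc(Cl)c2)CCCC1` gives 0.159 nM. Compound 3 `O=C1Cc2cc(NC(=O)[C@H]3CCCN3C(=O)C3(c4cccc(Cl)c4)CCCC3)ccc2N1` gives 0.794 nM, which places it second highest of the three: the two steps reaching it are a 2.5-fold lower number from compound 1 to compound 3 (0.40 log units; beyond the scatter) and a 5.0-fold higher number from compound 2 to compound 3 (0.70 log units; beyond the scatter), and between the other pair the step is a 13-fold lower number from compound 1 to compound 2 (1.10 log units; beyond the scatter).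

The next compound, compound 4 `COc1ccc(NC(=O)[C@H]2CCCN2C(=O)C2(c3cccc(Cl)c3)CCCC2)cc1`, is reached from compound 3 by a single change: a group of 8 heavy atoms (7 carbon, 1 oxygen; one six-membered aromatic ring of carbon only) in place of a group of 10 heavy atoms (8 carbon, 1 nitrogen, 1 oxygen; one five-membered non-aromatic ring with 1 hetero atom, one six-membered aromatic ring of carbon only), on an amide-type nitrogen. Going by the values given here, no measured step covers exactly this exchange. The closest guide is the reverse of the step from compound 1 to compound 3, where a single six-membered ring carrying a methoxy group gave a modestly higher number than the fused bicyclic group. Compound 4 carries such a ring as well, though without the ring nitrogen of compound 1, so the direction is expected to be upward, by a modest amount, with the ring-nitrogen difference left uncalibrated and widening the range.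

For compound 4 the expected step is a 5.0-fold higher number from compound 3 to compound 4 (0.70 log units; beyond the scatter), and its estimated value in this assay is 4 nM, within a range from 1 nM to 16 nM.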

Compound 4, half-maximal inhibitory concentration: 100 nM
Estimate against measurement, compound 4: 25-fold (1.40 log units) below; measured number outside the range, above it.
By their numbers in this assay, from the lowest: compound 2; then compound 3; then compound 1; then compound 4.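

In this assay the cleanest comparison is a 50-fold higher number from compound 1 to compound 4 (1.70 log units; beyond the scatter) and it turns on one exchange, 4-methoxyphenyl in place of 5-methoxypyridin-2-yl on the amide-type nitrogen, so a ring nitrogen that had seemed a minor difference between these two groups goes with a large change in the number. The other two steps, a 130-fold higher number from compound 3 to compound 4 (2.10 log units; beyond the scatter) and a 630-fold higher number from compound 2 to compound 4 (2.80 log units; beyond the scatter), are also large, yet compound 3 goes against any simple rule that a nitrogen in the aromatic ring is needed: its aromatic ring is carbon only, and its number still stays far lower than that of compound 4. Nothing available here accounts for the size of these steps.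

From the compounds shown here alone, it remains open whether a methoxy-free phenyl ring, or one carrying an amine or a hydroxyl group in place of the methoxy, would bring the number back down. Equally open, going by these compounds, is whether the pyridine ring of compound 1 needs its methoxy at all, and how a fluorine or a plain hydrogen in that place would compare.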